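The source may report more compounds than this note shows. Statements on the series, on what has been measured and on what is new or still open speak of the compounds shown alone.

Within the data shown here, compound 2, `O=C(O)Cc1sc(C(c2ccc(F)cc2)c2ccc(F)cc2)nc1-c1ccnc(Cl)c1`, stands at the lower end of the two numbers measured so far. In an in vitro functional assay on HEK285-7 cells for antagonist activity at prostaglandin D2 receptor 2 (Homo sapiens), read by BRET and beta-arrestin recruitment (a higher number here means a weaker inhibitor, a lower number a stronger inhibitor), compound 2 gives 39 nM. Among the measured compounds shown here, compound 1, `O=C(O)Cc1sc(C(c2ccc(F)cc2)c2ccc(F)cc2)nc1-c1cn[nH]c1`, gives 220 nM in this assay, and the only measured step, a 5.6-fold lower number from compound 1 to compound 2 (0.75 log units; beyond the scatter), exchanged the whole five-membered ring for the 2-chloropyridin-4-yl group.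

Compound 3, `Cc1cc(-c2nc(C(c3ccc(F)cc3)c3ccc(F)cc3)sc2CC(=O)O)ccn1`, keeps that six-membered ring and changes only one substituent on it: methyl in place of chloro on an aromatic carbon. For the measured compounds named here, no measured step swaps a chloro for a methyl, so the one known step bears on it only loosely: it shows that the pyridine ring is well tolerated, but not what the substituent on it contributes. The expectation is therefore a step in this assay of about a 1.3-fold higher number from compound 2 to compound 3 (0.11 log units; within the scatter), which is no more than the scatter. Compound 3 is estimated at 50 nM, within the range 18 nM to 140 nM.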

Compound 3, half-maximal inhibitory concentration: 53 nM
Beside the measured number, compound 3's estimate is 1.1-fold (0.03 log units) below it, within the range that was stated.
By their numbers in this assay, from the lowest: compounds 2 and 3 (each within the scatter of the next); then compound 1.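

In this assay, exchanging chloro for methyl on the aromatic carbon next to the ring nitrogen gives a 1.4-fold higher number from compound 2 to compound 3 (0.13 log units; within the scatter), so these two groups, each of one heavy atom, cannot be told apart at this position. The advantage of the six-membered ring over the five-membered one therefore does not depend on the chlorine: 2-methylpyridin-4-yl in place of 1H-pyrazol-4-yl also gives a 4.2-fold lower number from compound 1 to compound 3 (0.62 log units; beyond the scatter), which lies beyond the scatter. No measurement at hand explains why the two substituents read alike or why either pyridine ring outperforms the pyrazole ring.

Going by these compounds, what a plain hydrogen at this position would give remains open, so it is unknown whether a substituent is needed there at all. Also open, on these data alone, is whether a methoxy group, an amine or a trifluoromethyl group would read like chloro and methyl.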